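A Geometric Switch on the Alkylidene Double Bond

The compounds below may be only part of what the source reports. "The series", "measured", "known", "first", "only" and "open" are said of these compounds alone.

Compound 1 `O=Cc1cccc(OCc2cn(Cc3ccccc3)nn2)c1` is a fragment of the series. In a functional assay on MDA-MB-231 cells (Homo sapiens) for inhibition, read by MTT assay, with a stated time of 48 h (a higher number here means a weaker inhibitor, a lower number a stronger inhibitor), compound 1 gives > 50000 nM, a limit of the assay. Compound 2 `COc1cc(Cn2cc(COc3cccc(/C=C4\C(=O)Nc5ccccc54)c3)nn2)cc(OC)c1` is the fuller molecule. In this assay compound 2 gives > 50000 nM, likewise a limit. Both values thus sit at the same boundary (the limit of > 50000 nM in this assay, at which 2 of the 2 values shown sit). Compound 3 `COc1cc(Cn2cc(COc3cccc(/C=C4/C(=O)Nc5ccccc54)c3)nn2)cc(OC)c1` keeps every atom and bond of compound 2; (the two compounds have the same atoms and bonds and differ only in configuration as drawn: 1 of 1 stereo elements differ; a double bond is drawn Z in compound 2 and E in compound 3). Among the compounds with values here, with no measured step between compounds to lean on, the step from compound 2 to compound 3 is expected to stay at or near the limit, with a number no higher from compound 2 to compound 3 (the limit leaves the size open) as the estimated change. Compound 3 is therefore expected to give about 50000 nM in this assay, with a range from 10000 nM to 100000 nM.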

Compound 3, half-maximal inhibitory concentration: 11700 nM
Compound 3: the middle estimate sits 4.3-fold (0.63 log units) above what was measured; the measured number falls inside the stated range.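

In this assay, the configuration of the alkylidene double bond alone brings the read-out off the boundary, with an at least 4.2-fold lower number from compound 2 to compound 3 (0.63 log units; beyond the scatter). Neither earlier compound could show this, since both stand at a limit, and here the change can be traced to a single feature: the fact that compounds 2 and 3 differ only in the configuration as drawn. The value of compound 2 is a limit, so the full size of this step is not fixed.

The compounds shown leave open whether the E double bond keeps this advantage when an amine or a carboxylic acid replaces the methoxy groups.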